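A few compounds are considered here, and "the series" means these few. Any claim that something is new, unique, unknown or untested is made for them only; others in the source may bear on it.

Compound 3, `CC(C)(C)c1ccc(C(=O)/C=C/c2ccc([N+](=O)[O-])o2)cc1`, is the compound needing the most material in a functional assay on U-251 cells (Homo sapiens) for inhibition, read by sulforhodamine B assay, with a stated time of 72 h; a higher number here means that more compound is needed for the effect, a lower number that less compound is needed: compound 3 gives 44500 nM, the highest of the three numbers measured. The nearest measured compound, compound 2, `O=C(/C=C/c1ccc([N+](=O)[O-])o1)c1ccc(I)cc1`, gives 12500 nM, and the furthest, compound 1, `CCC(=O)Oc1cccc2ccc(/C=C/c3ccccc3[N+](=O)[O-])nc12`, which has a different core, gives 10100 nM. Among the measured compounds shown here, the single step between compounds differing in one place, a 3.6-fold higher number from compound 2 to compound 3 (0.55 log units; beyond the scatter), shows that the group on the aromatic carbon of the six-membered ring of compound 3 matters for this assay, with the tert-butyl compound needing more material than the iodo compound.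

Compound 4, `O=C(/C=C/c1ccc([N+](=O)[O-])o1)c1ccc(N2CCCC2)cc1`, differs from compound 3 by pyrrolidin-1-yl in place of tert-butyl on an aromatic carbon. For the measured compounds named here, the step from compound 2 to compound 3 bears on it only in that it marks the same position as sensitive; no measured step tells how pyrrolidin-1-yl compares with tert-butyl. Because compound 3 sits at the top of the measured numbers with 44500 nM, compound 4 is expected to come out somewhat lower, the expected change being a 3.0-fold lower number from compound 3 to compound 4 (0.47 log units; beyond the scatter). Compound 4 is estimated at 15000 nM, between 4000 nM and 50000 nM.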

Compound 4, half-maximal effective concentration: 35900 nM
Estimate against measurement, compound 4: 2.4-fold (0.38 log units) below; measured number inside the range.
By their numbers in this assay, from the lowest: compounds 1 and 2 (each within the scatter of the next); then compounds 4 and 3 (each within the scatter of the next).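

Placing pyrrolidin-1-yl where tert-butyl stood, on an aromatic carbon para to a large group, gives a 1.2-fold lower number from compound 3 to compound 4 (0.09 log units; within the scatter), so in this assay the two groups cannot be told apart, even though pyrrolidin-1-yl brings a five-membered non-aromatic ring and a hydrogen-bond acceptor that tert-butyl lacks. Iodo stays apart from both, with a 2.9-fold higher number from compound 2 to compound 4 (0.46 log units; beyond the scatter) alongside a 3.6-fold higher number from compound 2 to compound 3 (0.55 log units; beyond the scatter). Among these three groups, only the iodo compound stands apart at this position. Nothing available here accounts for this result.

The compounds shown leave open whether the lower number of compound 2 belongs to iodo in particular or would also come with bromo or chloro at this position. They also leave open how a carboxylic acid or a primary amine on the same carbon would compare.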